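This account rests on a few compounds, and the source may have more. Where it says the series, first, only, none or still open, it means among the compounds named here.

Compound 1 `Cc1ccccc1C(=O)Nc1nc(-c2ccccn2)cs1` gives 6300 nM
Compound 2 `O=C(Nc1nc(-c2ccccn2)cs1)c1ccc(Cl)cc1` gives "not determined" (no result reported)

Within the data shown here, in an ADME assay on Vero cells (Chlorocebus sabaeus) for cytotoxicity, read by MTT assay, with a stated time of 72 h (a higher number here means that more compound is needed for the effect, a lower number that less compound is needed), compound 1 gives 6300 nM as its half-maximal effective concentration, and this is the only number available so far. Compound 2 stands without a number: its entry reads "not determined" (no result reported) and so it cannot be ranked against compound 1.

Compound 3 `O=C(Nc1nc(-c2ccccn2)cs1)c1cccc(F)c1` is still to be measured. The change is 3-fluorophenyl in place of 4-chlorophenyl on a carbonyl carbon and it puts 3-fluorophenyl in place of 4-chlorophenyl on a carbonyl carbon. Among the measured compounds shown here, no two measured compounds differ in one place only, so the data do not show how large such an exchange can be. On that thin basis, the step expected in this assay is none beyond the usual scatter, in either direction, although compound 2 offers no number to count it from. The estimate leans on compound 1 at 6300 nM alone and is kept wide. The expected value for compound 3 is 7000 nM and the estimate spans 2500 nM to 20000 nM as its lower and upper ends.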

Compound 3, half-maximal effective concentration: 1200 nM
Estimate against measurement, compound 3: 5.8-fold (0.77 log units) above, and the stated range ends above it.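

In this assay, the group on the carbonyl carbon proves able to shift the result: the exchange of 2-methylphenyl for 3-fluorophenyl gives a 5.3-fold lower number from compound 1 to compound 3 (0.72 log units; beyond the scatter), a step beyond the usual scatter and the first one at this place whose size can be read. It is a single step between two compounds with the core of compound 1 unchanged, so it shows that this place responds to an exchange of aryl groups but establishes no trend across them. The exchange of 4-chlorophenyl for 3-fluorophenyl cannot be read, as compound 2 has no number, and no measurement given here explains the step from the 2-methylphenyl compound to the 3-fluorophenyl compound.

The step from compound 1 to compound 3 replaces a methyl group with a fluorine atom and also moves the substituent to a different ring position, leaving open which of these two differences accounts for the size of the step. The compounds shown also leave open how 2-fluorophenyl, 3-methylphenyl or 3-aminophenyl would compare at this carbonyl carbon.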